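The source may report more compounds than this note shows. Statements on the series, on what has been measured and on what is new or still open speak of the compounds shown alone.

Of the compounds shown here, two of the shared core have been measured so far. Compound 2 `CC(C)c1ccc(NC(=S)OCCc2ccccn2)cc1` carries an isopropyl group on its aromatic ring, and in an ADME assay on MT4 cells (Homo sapiens) for cytotoxicity, read by MTT assay (a lower number here means that less compound is tolerated, a higher number that more compound is tolerated), compound 2 gives 45000 nM. Compound 1 `S=C(Nc1ccccc1Cl)OCCc1ccccn1` reaches only a limit of the assay: in this assay compound 1 gives > 100000 nM, which is a limit and not a number. Among the values shown, compound 2 therefore stands as the only actual number, while the other value sits at the limit of > 100000 nM in this assay, at which 1 of the 2 values shown sits. Compound 3 `Fc1ccc(NC(=S)OCCc2ccccn2)cc1` is the next compound, not yet measured. It differs from compound 2 by fluoro in place of isopropyl on an aromatic carbon. Among the compounds with values here, with no step between measured compounds to lean on, the step from compound 2 to compound 3 in this assay is expected to be a 1.8-fold higher number from compound 2 to compound 3 (0.25 log units; within the scatter), toward more compound tolerated. Compound 3 is thus estimated at 80000 nM, with a range from 30000 nM to 200000 nM.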

Compound 3, half-maximal cytotoxic concentration: > 100000 nM
Compound 3: no number, only a limit; the forecaster's own chance of this, stated with the estimate: 40%; middle value at least 1.2-fold (0.09 log units) from the limit.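

Swapping isopropyl for fluoro at this position, para to a large group, gives a first readable step in this assay: an at least 2.2-fold higher number from compound 2 to compound 3 (0.34 log units; beyond the scatter). As far as these compounds go, compound 3 gives > 100000 nM, which is a limit of the assay and not a number, and the full size of the change therefore stays unknown. Even so, the direction is fixed and the step lies beyond the scatter, showing that the group at this position can change how much compound the cells tolerate.

This single pair cannot tell which difference between isopropyl and fluoro matters, nor whether an amine or a methoxy group at the same position would fall near compound 2 or compound 3. Further gains toward more compound tolerated may be hard to see in this series: the limit of > 100000 nM in this assay, at which 2 of the 3 values shown sit.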